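This account rests on a few compounds, and the source may have more. Where it says the series, first, only, none or still open, it means among the compounds named here.

Three compounds share one core. Compound 1 `FC(F)(F)c1ccc(Nc2nc(-c3ccc(Cl)cc3)cs2)cc1` carries a trifluoromethyl group; in an assay on isolated protein for inhibition of Polyunsaturated fatty acid 5-lipoxygenase (Homo sapiens), with stated times of 15 min and 10 min (on this read-out lower numbers stand for stronger inhibition and higher numbers for weaker inhibition), compound 1 gives 5900 nM. Compound 2 `Oc1ccc(Nc2nc(-c3ccc(Cl)c(Cl)c3)cs2)cc1` gives 900 nM in this assay. Compound 3 `Oc1cccc(Nc2nc(-c3ccc(Cl)cc3)cs2)c1` gives 5600 nM in this assay; it stands second highest of the three numbers, with compound 1 nearest, within the scatter, and compound 2 furthest, beyond the scatter, at a lower number. For the measured compounds named here, no pair of measured compounds differs in only one place, so the change to compound 4 `Oc1cccc(Nc2nc(-c3ccccc3)cs2)c1` has no measured precedent in this set. The change from compound 3 is hydrogen in place of chloro on an aromatic carbon. Compound 2 and compound 3 show that the compound with two chloro groups has the lower number, but the two also differ in where the hydroxy sits, so only that can be said. Taking away the chloro is expected to raise the number somewhat, and the step from compound 3 to compound 4 is estimated at a 2.1-fold higher number from compound 3 to compound 4 (0.33 log units; beyond the scatter). Compound 4 is accordingly expected near 12000 nM, within the range 4000 nM to 35000 nM.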

Compound 4, half-maximal inhibitory concentration: 8300 nM
Estimate against measurement, compound 4: 1.4-fold (0.16 log units) above; the measured number falls inside the stated range.
By their numbers in this assay, from the lowest: compound 2; then compounds 3, 1 and 4 (each within the scatter of the next).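

In this assay, for the compounds shown here, the first pair that differs in one place gives a 1.5-fold higher number from compound 3 to compound 4 (0.17 log units; within the scatter), so hydrogen in place of chloro on this aromatic carbon, para to a large group, produces no change beyond the scatter. In this pair, with the rest of the structure unchanged, the chloro is therefore not required for inhibition at this level. Nothing available bears on why this step is so small.

Going by these compounds, it remains open whether another group at this position, such as a methoxy group, an amine or a carboxylic acid, would shift the number beyond the scatter. On these data alone, it is also open whether the same replacement would give a similar step with the hydroxy group placed as in compound 2, or with the trifluoromethyl group of compound 1.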